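The source may hold more compounds than are shown below. What is called first, only, known or untested is meant among the compounds shown, and "the series" means these compounds.

Measured so far in an ADME assay on L02 cells (Homo sapiens) for antiproliferative activity, read by MTT assay, with a stated time of 48 h; a higher number here means a weaker inhibitor, a lower number a stronger inhibitor:

Compound 1 `N#CC1=C(N)Oc2c(N)cc3nc4ccccc4nc3c2C12C(=O)N(Cc1cnnn1-c1ccc(F)cc1)c1ccccc12`: the value is a limit of the assay, > 50000 nM.
Compound 2 `N#CC1=C(N)Oc2c(N)cc3nc4ccccc4nc3c2C12C(=O)N(Cc1cnnn1-c1ccccc1Br)c1ccccc12`: 29200 nM.
Compound 3 `N#CC1=C(N)Oc2c(N)cc3nc4ccccc4nc3c2C12C(=O)N(Cc1cnnn1-c1cccc(C(F)(F)F)c1)c1ccccc12`: 38100 nM.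

Compound 3 carries the highest of the two numbers shown; the nearest is compound 2, and a 1.3-fold higher number from compound 2 to compound 3 (0.12 log units; within the scatter), so the two sit within the scatter of each other. Compound 1 stands only at the limit of > 50000 nM in this assay, at which 1 of the 3 values shown sits.

The next member is compound 4 `CCOc1ccccc1-n1nncc1CN1C(=O)C2(C(C#N)=C(N)Oc3c(N)cc4nc5ccccc5nc4c32)c2ccccc21`. The change from compound 3 is 2-ethoxyphenyl in place of 3-(trifluoromethyl)phenyl on an aromatic nitrogen.

All three measured steps change the same aryl group on that aromatic nitrogen: an at least 1.7-fold lower number from compound 1 to compound 2 (0.23 log units; that floor lies within the scatter), an at least 1.3-fold lower number from compound 1 to compound 3 (0.11 log units; that floor lies within the scatter) and a 1.3-fold higher number from compound 2 to compound 3 (0.12 log units; within the scatter). None of these reaches beyond the scatter, so a swap of one aryl for another at this position is expected to leave this assay largely unchanged, with no step beyond the scatter in either direction.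

Compound 4 is therefore estimated at 35000 nM, with a range of 17000 nM to 60000 nM. The step this estimate means, a 1.1-fold lower number from compound 3 to compound 4 (0.04 log units; within the scatter), is expected to stay within the scatter.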

Compound 4, half-maximal inhibitory concentration: > 50000 nM
Compound 4: only a limit was reported; the forecaster's own chance of this, stated with the estimate: 30%; middle value at least 1.4-fold (0.15 log units) from the limit.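

Compound 4 is a second member at the limit of the assay in this assay: the limit of > 50000 nM in this assay, at which 2 of the 4 values shown sit. With ethoxy in place of bromo, the series shows an at least 1.7-fold higher number from compound 2 to compound 4 (0.23 log units; that floor lies within the scatter), and with 2-ethoxyphenyl in place of 3-(trifluoromethyl)phenyl it shows an at least 1.3-fold higher number from compound 3 to compound 4 (0.11 log units; that floor lies within the scatter); both floors lie within the scatter, so an ethoxy group on this aryl ring gives no sign of a lower number, though neither step is shown to exceed the scatter. The step between compound 1 and compound 4 cannot be read, as both are limits.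

As far as these compounds go, how far compound 4 lies from compound 2 and compound 3 stays open, since only a floor is available. Also open, from the compounds shown here alone, is whether an amine or a carboxylic acid on this phenyl ring, or a longer chain in place of ethoxy, would move the number beyond the scatter.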